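A few compounds are considered here, and "the series" means these few. Any claim that something is new, unique, unknown or untested is made for them only; others in the source may bear on it.

Compound 1 `O=C(CCCCCCCNC(=O)c1cc(=O)c(O)co1)Nc1ccccc1`: in a functional assay on HCT-116 cells (Homo sapiens) for inhibition, read by colorimetric assay, with a stated time of 3 days (on this read-out lower numbers stand for stronger inhibition and higher numbers for weaker inhibition), compound 1 gives > 100000 nM, which is a limit of the assay rather than a number.
Compound 2 `CCOc1ccc(-c2cnc(NC(=O)CCCCCCNC(=O)C(O)(O)C(F)(F)F)s2)cc1`: in this assay compound 2 gives 4050 nM.

Within the data shown here, compound 2 therefore stands as the only real number in this set; the one other result, (the limit of > 100000 nM in this assay, at which 1 of the 2 values shown sits), is a limit and not a measured value. Among the measured compounds shown here, no pair of measured compounds differing in a single place is available, so no measured step can serve as a guide.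

Compound 3 `O=C(CCCCCCNC(=O)C(O)(O)C(F)(F)F)Nc1ncc(-c2ccccc2)s1` differs from compound 2 by hydrogen in place of ethoxy on an aromatic carbon. Without a measured comparison, the expectation rests on the size of the change alone: a small group is removed from the edge of the molecule, so a step of a 1.7-fold higher number from compound 2 to compound 3 (0.24 log units; within the scatter) toward slightly weaker inhibition, near the usual scatter, is expected. Compound 3 is thus estimated at 7000 nM, with a range from 2000 nM to 25000 nM.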

Compound 3, half-maximal inhibitory concentration: 2660 nM
Compound 3: the middle estimate sits 2.6-fold (0.42 log units) above what was measured; low and high end bracket the measured number.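

In this assay, going from 4-ethoxyphenyl to phenyl gives a 1.5-fold lower number from compound 2 to compound 3 (0.18 log units; within the scatter) and so makes no measurable difference on this read-out. Among these compounds, this is the first direct look at this place on the six-membered aromatic ring, and it shows that compound 3 keeps its inhibition of these cells without the ethoxy group, with only a hydrogen there. The compounds at hand offer no reason for this result.

Ethoxy and hydrogen are the only two groups compared at this place, so it remains open whether an amine, a carboxylic acid, a chlorine atom or a longer chain such as butoxy would also leave the number unchanged. As far as these compounds go, it is equally open whether the same change would have as little effect on a compound with a different chain length.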